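The compounds below may be only part of what the source reports. "The series", "measured", "known", "first", "only" and "open" are said of these compounds alone.

Compound 1 `COc1cc(-c2cc(/C=C/C(=O)c3ccc(N)cc3)[nH]n2)cc(OC)c1OC` gives 62% in a functional assay on OVCAR-4 cells (Homo sapiens) for cytotoxicity, read by sulforhodamine B assay, with a stated time of 48 h, tested at 1 uM; on this read-out lower numbers stand for a stronger effect and higher numbers for a weaker effect at the one concentration tested. Compound 2 `COc1ccc(C(=O)/C=C/c2cc(-c3cc(OC)c(OC)c(OC)c3)n[nH]2)cc1` gives 80%.

Going by the values given here, compound 2 holds the highest of the two numbers; the only measured step, a number 18 percentage points higher from compound 1 to compound 2 (beyond the scatter), runs to it from compound 1. Compound 3 `COc1cc(-c2cc(/C=C/C(=O)c3ccc(F)c(F)c3)[nH]n2)cc(OC)c1OC` is unmeasured and differs from compound 2 by 3,4-difluorophenyl in place of 4-methoxyphenyl on a carbonyl carbon. Among the compounds with values here, no measured step swaps a methoxy for two fluorines, so the step from compound 1 to compound 2 bears on the same part of the molecule but not on this change, and a step of no more than the usual scatter is expected, a number 8 percentage points lower from compound 2 to compound 3 (within the scatter). Compound 3 is therefore estimated at 72%, between 50% and 95%.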

Compound 3, a percentage reported as activity, at one concentration (the size of the read-out at that concentration, not a potency): 67%
For compound 3 the middle estimate is 5 percentage points above the measured one, within the range that was stated.
By their numbers in this assay, from the lowest: compounds 1 and 3 (each within the scatter of the next); then compound 2.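

On the aryl group at the carbonyl carbon in this assay, 3,4-difluorophenyl in place of 4-methoxyphenyl gives a number 13 percentage points lower from compound 2 to compound 3 (beyond the scatter), so the stronger effect is not confined to the compound carrying 4-aminophenyl. Swapping 4-aminophenyl for 3,4-difluorophenyl gives a number 5 percentage points higher from compound 1 to compound 3 (within the scatter), which leaves these two groups indistinguishable here and compound 2 alone at the weak end. Nothing available explains why these groups rank this way. Open, as far as these compounds go, is where an unsubstituted phenyl, a hydroxyl or a carboxylic acid at this place would fall.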